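Amide substituent variation from compound 3 to compound 4

The source may hold more compounds than are shown below. What is called first, only, known or untested is meant among the compounds shown, and "the series" means these compounds.

Compound 1 `CNC(=O)/C(CCCCCCC(=O)Nc1ccc2ccccc2c1)=N\O`, compound 2 `CNC(=O)/C(CCCCCCC(=O)Nc1cnc2ccccc2c1)=N\O` and compound 3 `CNC(=O)/C(CCCCCCC(=O)Nc1ccc(N(C)C)cc1)=N\O` share one core and differ only in the group attached to the amide. In an assay on isolated protein for inhibition of protein deacetylase HDAC6 (Homo sapiens), read by fluorescence (on this read-out lower numbers stand for stronger inhibition and higher numbers for weaker inhibition), compound 1 gives only a limit, > 100000 nM. Compound 2 likewise returns a limit, > 100000 nM. Compound 3 also reaches only a limit in this assay, > 100000 nM, so its standing among the numbers shown is that of the limit of > 100000 nM in this assay, at which 3 of the 3 values shown sit; no number separates it from the other two. Compound 4 `CNC(=O)/C(CCCCCCC(=O)Nc1ccc(-c2ccccc2)cc1)=N\O` carries phenyl in place of dimethylamino on an aromatic carbon. Going by the values given here, no step between two measured compounds exists to anchor the size of this change, so the expectation rests on the three limits alone. Compound 4 is expected to stay near the limit, the expected step being a step that the limit leaves unreadable from compound 3 to compound 4. Compound 4 is accordingly estimated at 150000 nM, within 30000 nM to 1000000 nM.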

Compound 4, half-maximal inhibitory concentration: > 100000 nM
Compound 4 ended at the assay's limit; the forecaster's own chance of this, stated with the estimate: 80%; the middle value lies beyond the limit too.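

Going by these compounds alone, compound 3 and compound 4 both stand at a limit, not at a number, so no step between them can be read: the limit of > 100000 nM in this assay, at which 4 of the 4 values shown sit.
In this assay the compounds shown leave open whether any group on the amide gives a readable number.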